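The source may report more compounds than this note shows. Statements on the series, on what has been measured and on what is new or still open speak of the compounds shown alone.

Measured so far:
compound 1 `COc1ccc(-n2nc(C(=O)Nc3ccc(Oc4ccnc5cc(OCCCN6CCN(C)CC6)c(OC)cc45)c(F)c3)c(C)cc2=O)cc1`: 2200 nM
compound 2 `COc1cc2c(Oc3ccc(NC(=O)c4nn(-c5ccc(Cl)cc5)c(=O)cc4C)cc3F)ccnc2cc1OCCCN1CCCCC1`: 320 nM

In a functional assay on A549 cells (Homo sapiens) for inhibition, read by MTT assay, with a stated time of 72 h (on this read-out lower numbers stand for stronger inhibition and higher numbers for weaker inhibition), compound 2 gives 320 nM and holds the lowest number of the two. Compound 1 differs from compound 2 in more than one place. In this assay compound 1 gives 2200 nM, a gap beyond the scatter. Compound 3 `COc1cc2c(Oc3ccc(NC(=O)c4nn(-c5ccc(Cl)cc5)c(=O)cc4C)cc3F)ccnc2cc1OCCCN1CCN(C)CC1` carries 4-methylpiperazin-1-yl in place of piperidin-1-yl on a saturated chain carbon, three bonds along the chain from an oxygen on an aromatic ring. Among the measured compounds shown here, no measured pair isolates this change, so nothing here fixes its size. The step from compound 2 to compound 3 is expected to be small, a 1.6-fold higher number from compound 2 to compound 3 (0.19 log units; within the scatter), leaning toward a weaker number but possibly within the scatter. For compound 3 the expected value in this assay is 500 nM, with a range from 150 nM to 1800 nM.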

Compound 3, half-maximal inhibitory concentration: 270 nM
Compound 3: the middle estimate sits 1.9-fold (0.27 log units) above what was measured; the range from low to high includes it.
By their numbers in this assay, from the lowest: compounds 3 and 2 (each within the scatter of the next); then compound 1.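

In this assay, 3-(4-methylpiperazin-1-yl)propyl in place of 3-(piperidin-1-yl)propyl gives a 1.2-fold lower number from compound 2 to compound 3 (0.07 log units; within the scatter), so this position shows no readable difference between the two rings. With 4-methylpiperazin-1-yl held constant, chloro in place of methoxy on an aromatic carbon gives an 8.1-fold lower number from compound 1 to compound 3 (0.91 log units; beyond the scatter), which isolates the gap as a change at that aromatic carbon. Nothing available explains either step. Open, from the compounds shown here alone, is whether morpholin-4-yl or dimethylamino on the chain, or a longer chain, would stay within the scatter. Also open, going by these compounds, is how fluoro or trifluoromethyl compares with chloro at that aromatic carbon.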